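A few compounds are considered here, and "the series" means these few. Any claim that something is new, unique, unknown or untested is made for them only; others in the source may bear on it.

Compound 1, `CC(C)Cn1c(=O)n(C)c(=O)c2[nH]c(=O)c(Cc3cccc4ccccc34)nc21`, sits at a limit of a functional assay on Raji cells (Homo sapiens) for inhibition, read by MTT assay, with a stated time of 96 h (on this read-out lower numbers stand for an effect already at smaller amounts and higher numbers for an effect only at larger amounts of compound), rather than at a measured number: it gives > 10000 nM. Compound 2, `CC(C)Cn1c(=O)n(C)c(=O)c2c1nc(Cc1cccc3ccccc13)c(=O)n2CCCCO`, carries a 4-hydroxybutyl group in place of hydrogen on an aromatic nitrogen of that core, and in this assay it gives 150 nM. The step of an at least 66-fold lower number from compound 1 to compound 2 (1.82 log units; beyond the scatter) shows how much a hydroxyalkyl chain at that position can shift the read-out, and the limit itself is described by the limit of > 10000 nM in this assay, at which 2 of the 3 values shown sit. Compound 3, `CC(C)Cn1c(=O)n(C)c(=O)c2nc(C(=O)NCCCO)c(Cc3cccc4ccccc34)nc21`, also stands only at a limit: in this assay it gives > 10000 nM. Compound 4, `CC(C)Cn1c(=O)n(C)c(=O)c2nc(-c3[nH]nnc3CCCO)c(Cc3cccc4ccccc34)nc21`, differs from compound 3 in one place: 4-(3-hydroxypropyl)-1H-1,2,3-triazol-5-yl in place of (3-hydroxypropyl)carbamoyl on an aromatic carbon. For the measured compounds named here, no measured step concerns this kind of exchange on an aromatic carbon, so the one measured step, from compound 1 to compound 2, gives no direct guide; the hydroxypropyl chain is kept, and the chain in compound 2 is what the measured step speaks for. Compound 4 is therefore expected to remain weak, near the limit, with an estimated 8000 nM and a range from 1500 nM to 30000 nM, the expected step being an at least 1.2-fold lower number from compound 3 to compound 4 (0.09 log units; that floor lies within the scatter).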

Compound 4, half-maximal effective concentration: 6020 nM
Compound 4: middle estimate off by 1.3-fold (0.12 log units), on the high side; measured number inside the range.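

On the aromatic carbon ortho to the (naphthalen-1-yl)methyl group, 4-(3-hydroxypropyl)-1H-1,2,3-triazol-5-yl in place of (3-hydroxypropyl)carbamoyl turns a limit into a measured number in this assay, with an at least 1.6-fold lower number from compound 3 to compound 4 (0.22 log units; that floor lies within the scatter). This shows that a group carrying a five-membered aromatic ring is compatible with a measurable effect at this position, while the hydroxypropyl chain stays in both compounds. Whether the change is a real gain remains unsettled, because the step starts from a limit and can be read only as a floor: the limit of > 10000 nM in this assay, at which 2 of the 4 values shown sit.

The compounds shown leave open how this assay would respond if an amine, a carboxylic acid or a longer chain took the place of the hydroxypropyl chain on that five-membered ring. They also leave open whether the ring would give a measured number without any such chain.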